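Thiophen-3-yl replaces 1-methylethenyl in a pinane amine series

The source may report more compounds than this note shows. Statements on the series, on what has been measured and on what is new or still open speak of the compounds shown alone.

The compounds share a bicyclic amine core bearing a methyl and a gem-dimethyl bridge, linked through a methylene to a substituted thiophene. Compound 1 `C[C@H]1[C@H](NCc2ccc(C(C)(C)C)s2)C[C@H]2C[C@@H]1C2(C)C` carries a tert-butyl group on the thiophene, compound 2 `C=C(C)c1csc(CN[C@@H]2C[C@H]3C[C@@H]([C@H]2C)C3(C)C)c1` a 1-methylethenyl group, and compound 3 `CCCCc1ccsc1CN[C@@H]1C[C@H]2C[C@@H]([C@H]1C)C2(C)C` a butyl chain. In an ADME assay on MDCK cells (Canis lupus familiaris) for cytotoxicity, read by microscopy, with a stated time of 48 h (on this read-out higher numbers stand for lower toxicity in this test and lower numbers for higher toxicity in this test), compound 1 gives 780 nM. In this assay compound 2 gives 25000 nM, and compound 3 gives 25000 nM. Compound 2 thus stands level with compound 3 at the digits shown, the two together forming the highest numbers of the three, whereas compound 1 lies a clear step lower, beyond the scatter.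

Compound 4 `C[C@H]1[C@H](NCc2cc(-c3ccsc3)cs2)C[C@H]2C[C@@H]1C2(C)C` has not yet been measured in this assay. It differs from compound 2 in one place: thiophen-3-yl in place of 1-methylethenyl on an aromatic carbon. Among the measured compounds shown here, no step between two measured compounds reproduces this change, so the direction is open. Because compound 1 gives 780 nM with a bulkier substituent, a larger group may pull the number down, and a modest step downward is expected a 2.1-fold lower number from compound 2 to compound 4 (0.32 log units; beyond the scatter). For compound 4 the expected value is 12000 nM, with a range from 3000 nM to 30000 nM.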

Compound 4, minimum cytotoxic concentration: 25000 nM
For compound 4 the middle estimate is 2.1-fold (0.32 log units) below the measured one; low and high end bracket the measured number.
By their numbers in this assay, from the lowest: compound 1; then compounds 2, 3 and 4 (each within the scatter of the next).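

In this assay the exchange of 1-methylethenyl for thiophen-3-yl leaves the number unmoved, with no change at the digits printed from compound 2 to compound 4 (within the scatter). The position, an aromatic carbon two ring bonds from the ring sulfur, therefore takes a substituent of 5 heavy atoms, with a five-membered aromatic ring and 1 hydrogen-bond acceptor, in place of one of 3 heavy atoms with no ring and no acceptor, and the read-out stays within the scatter. Nothing given here explains why the number holds for this pair.

The compounds shown leave open whether an amine or a carboxylic acid on this same aromatic carbon, or a phenyl ring in place of thiophen-3-yl, would shift the number in this assay. They also leave open whether thiophen-3-yl would give the same outcome on another carbon of the ring that bears it here, since this pair speaks for one position only.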